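Chain rearrangement at the guanidine end of compound 2

The compounds below may be only part of what the source reports. "The series", "measured", "known", "first", "only" and "open" are said of these compounds alone.

Measured so far:
compound 1 `CC/N=C(/NC#N)NCCCn1nc(-c2ccccc2)cc(C)c1=O`: 23.5%
compound 2 `CC/N=C(/NC#N)NCCCn1nc(-c2ccccc2)ccc1=O`: 62.9%
compound 3 `CCC/N=C(/NC#N)NCCCn1nc(-c2ccccc2)ccc1=O`: 52.9%

In a functional assay on the whole organism with Rattus norvegicus as the target, at a dose of 100 mg/kg (a lower number here means less inhibition, a higher number more inhibition at the dose given (going by the name of the read-out)), compound 2 gives the highest of the three numbers. Its nearest neighbour is compound 3, where a number 10 percentage points lower from compound 2 to compound 3 (within the scatter) falls within the scatter; compound 1 lies furthest away, with a number 39.4 percentage points higher from compound 1 to compound 2 (beyond the scatter) beyond the scatter.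

Compound 4 `C/N=C(\NC#N)NCCCCn1nc(-c2ccccc2)ccc1=O` has not yet been measured. Compared with compound 2 the change is a group of 8 heavy atoms (4 carbon, 4 nitrogen; no ring) in place of a group of 8 heavy atoms (4 carbon, 4 nitrogen; no ring), on a saturated chain carbon, three bonds along the chain from an aromatic nitrogen, with the same atoms joined differently: a longer saturated chain toward the aromatic nitrogen, and a shorter alkyl on the double-bonded nitrogen.

Of the measured steps only a number 10 percentage points lower from compound 2 to compound 3 (within the scatter) bears on this change, since it also alters the alkyl on the double-bonded nitrogen, and it stayed within the scatter. Going by the values given here, no measured step tests a longer saturated chain toward the aromatic nitrogen, so that part of the change is uncovered.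

Compound 4 is therefore expected to show a number 7.9 percentage points lower from compound 2 to compound 4 (within the scatter), no step beyond the scatter, with a wide range. Compound 4 is estimated at 55%, between 30% and 75%.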

Compound 4, a percentage reported as inhibition, in the whole organism at one dose (the size of the read-out at that dose, not a potency): 79%
The estimate for compound 4 lay 24 percentage points below the measured number; the whole stated range lies below it.
By their numbers in this assay, from the lowest: compound 1; then compounds 3 and 2 (each within the scatter of the next); then compound 4.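

In this assay, joining the same atoms differently, with a longer saturated chain toward the aromatic nitrogen and a shorter alkyl on the double-bonded nitrogen, gives a number 16.1 percentage points higher from compound 2 to compound 4 (beyond the scatter) in this series. The earlier change to the alkyl on the double-bonded nitrogen alone gave a number 10 percentage points lower from compound 2 to compound 3 (within the scatter) and so showed no clear effect, whereas this rearrangement is the first step shown that raises the number from compound 2 beyond the scatter. Nothing presented here accounts for the rise.

Since the two parts of the change arrive together, the compounds shown cannot separate the contribution of the longer chain from that of the shorter alkyl. As far as these compounds go, how a still longer saturated chain toward the aromatic nitrogen, or a plain hydrogen in place of the alkyl on the double-bonded nitrogen, would read in this assay also remains open.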